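Shortening the ether chain on the piperidine side chain

A few compounds are considered here, and "the series" means these few. Any claim that something is new, unique, unknown or untested is made for them only; others in the source may bear on it.

Compound 2 `CCOCCOC[C@H]1CCCN(c2ccnc3sc(C(N)=O)c(N)c23)C1` gives the highest maximal plasma concentration of the two compounds measured in an ADME assay on the whole organism (Rattus norvegicus, strain Fischer 344) for pharmacokinetics, at a dose of 3 mg/kg by the oral route (a lower number here means less compound in the circulation, a higher number more compound in the circulation at the dose given), at 2120 nM; compound 1 `Cc1noc(COC[C@H]2CCCN(c3ccnc4sc(C(N)=O)c(N)c34)C2)n1` gives 393 nM, and the step of a 5.4-fold higher number from compound 1 to compound 2 (0.73 log units; beyond the scatter) is the only one measured. Compound 3 `COC[C@H]1CCCN(c2ccnc3sc(C(N)=O)c(N)c23)C1` differs from compound 2 by hydrogen in place of ethoxymethyl on a saturated chain carbon bound to an oxygen on a saturated carbon. Among the measured compounds shown here, no measured step swaps an ether chain for hydrogen at this place, and the one step recorded concerns a different group, so no direction beyond the scatter is firmly expected. Compound 3 is estimated at 1400 nM (range 450 nM to 4500 nM), a step of a 1.5-fold lower number from compound 2 to compound 3 (0.18 log units; within the scatter).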

Compound 3, maximal plasma concentration in the Rattus norvegicus assay: 251 nM
Beside the measured number, compound 3's estimate is 5.6-fold (0.75 log units) above it; the measured number lies below the stated range.
By their numbers in the Rattus norvegicus assay, from the lowest: compounds 3 and 1 (each within the scatter of the next); then compound 2.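

In the Rattus norvegicus assay, cutting (2-ethoxyethoxy)methyl back to methoxymethyl gives an 8.4-fold lower number from compound 2 to compound 3 (0.93 log units; beyond the scatter), so the ethoxymethyl part matters at this place. Putting hydrogen in place of 3-methyl-1,2,4-oxadiazol-5-yl gives a 1.6-fold lower number from compound 1 to compound 3 (0.19 log units; within the scatter), so among these three compounds only the ethoxymethyl group stands out. In a physicochemical assay for solubility, at pH 6.8 (a higher number here means a more soluble compound, a lower number a less soluble compound), compound 2 gives 500 ug/mL and compound 3 gives 220 ug/mL.

Open, going by these compounds, is whether a longer chain or an amine at this place would give a higher maximal plasma concentration than ethoxymethyl. One pair with both read-outs cannot show whether the two read-outs move together across the series.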